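The source may report more compounds than this note shows. Statements on the series, on what has been measured and on what is new or still open speak of the compounds shown alone.

Compound 3 `COc1ccc(C2=NN(C3=NC(=O)/C(=C4\C(=O)Nc5ccccc54)S3)C(c3ccc(Cl)cc3)C2)cc1` sits at the weak end of the three measured compounds: in a functional assay on cells (Cancer cell lines, Homo sapiens) for cytotoxicity, read by sulforhodamine B assay, with a stated time of 48 h (a higher number here means a weaker inhibitor of growth, a lower number a stronger inhibitor of growth), compound 3 gives 100000 nM, far above compound 1 `COc1ccc(C2=NN(C3=NC(=O)/C(=C4\C(=O)Nc5ccc(Cl)cc54)S3)C(c3ccc(OC)cc3)C2)cc1` at 210 nM and compound 2 `O=C1N=C(N2N=C(c3ccccc3)CC2c2ccc(Cl)cc2)S/C1=C1/C(=O)Nc2ccccc21` at 190 nM. Among the compounds with values here, the only measured single change, a 530-fold higher number from compound 2 to compound 3 (2.72 log units; beyond the scatter), shows how much one aromatic substituent can move this number. Compound 4 `COc1ccc(C2=NN(C3=NC(=O)/C(=C4\C(=O)Nc5ccc(Cl)cc54)S3)C(c3ccc(Cl)cc3)C2)cc1` differs from compound 3 by chloro in place of hydrogen on an aromatic carbon. Within the data shown here, no measured step isolates this change; compound 1 carries the same chloro but also differs elsewhere, so its value only hints at a lower number. Compound 4 is therefore expected to show a 33-fold lower number from compound 3 to compound 4 (1.52 log units; beyond the scatter), landing at an estimated 3000 nM, within 250 nM to 60000 nM.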

Compound 4, concentration for 50% growth inhibition: 210 nM
Compound 4: middle estimate off by 14-fold (1.15 log units), on the high side; measured number outside the range, below it.
By their numbers in this assay, from the lowest: compounds 2, 1 and 4 (each within the scatter of the next); then compound 3.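

Chloro in place of hydrogen on this six-membered aromatic ring, part of a fused system, gives a 480-fold lower number from compound 3 to compound 4 (2.68 log units; beyond the scatter) in this assay, so one atom at this position can offset almost all of the weakness of compound 3. Once this chloro is present, chloro in place of methoxy on an aromatic carbon gives no change at the digits printed from compound 1 to compound 4 (within the scatter), a swap that matters little in this setting.

On these data alone, whether fluoro, methyl or an amine at this position would act like chloro remains open. Nothing shown here explains the size of this step.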